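Working notes: methoxy to hydrogen on an aromatic carbon

The compounds below may be only part of what the source reports. "The series", "measured", "known", "first", "only" and "open" are said of these compounds alone.

The set is read in a functional assay on MDA-MB-231 cells (Homo sapiens) for cytotoxicity, read by sulforhodamine B assay, with a stated time of 48 h, tested at 0.01 uM; a higher number here means a weaker effect of the compound at the concentration tested, a lower number a stronger effect. Compound 1 `COc1cc(-c2cc(/C=C/C(=O)c3ccc(N)cc3)[nH]n2)cc(OC)c1OC` gives 109%. Compound 2 `COc1ccc(C(=O)/C=C/c2cc(-c3cc(OC)c(OC)c(OC)c3)n[nH]2)cc1OC` gives 104%, and compound 3 `COc1ccc(C(=O)/C=C/c2cc(-c3cc(OC)c(OC)c(OC)c3)n[nH]2)cc1` gives 104%. The three numbers sit close together: a number 5 percentage points lower from compound 1 to compound 2 (within the scatter), a number 5 percentage points lower from compound 1 to compound 3 (within the scatter), and no change at the digits printed from compound 2 to compound 3 (within the scatter). None of these compounds can be called stronger or weaker than another.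

Compound 4 `COc1ccc(-c2cc(/C=C/C(=O)c3ccc(N)cc3)[nH]n2)cc1OC` is not yet measured. The difference between compound 1 and compound 2 is on the carbonyl side: 4-aminophenyl in place of 3,4-dimethoxyphenyl on a carbonyl carbon. Among the measured compounds shown here, the change from compound 2 to compound 3, (hydrogen in place of methoxy on an aromatic carbon), is the same kind of change as the one from compound 1 to compound 4, (hydrogen in place of methoxy on an aromatic carbon), but not the same: in compound 4 the leaving methoxy also sits meta to a methoxy group, and the ring in question sits on the core rather than on the carbonyl carbon.

For compound 4 the step of a number 4 percentage points lower from compound 1 to compound 4 (within the scatter) is expected, resting on the measured step of no change at the digits printed from compound 2 to compound 3 (within the scatter), which gave no movement at the digits printed. The estimate for compound 4 in this assay is 105%, with a likely range from 92% to 118%, because compound 1 stands at 109% and nothing in the set has moved beyond the scatter.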

Compound 4, a percentage reported as activity, at one concentration (the size of the read-out at that concentration, not a potency): 113%
The estimate for compound 4 lay 8 percentage points below the measured number; the range from low to high includes it.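

In this assay, hydrogen in place of methoxy on an aromatic carbon of the core of compound 1 gives a number 4 percentage points higher from compound 1 to compound 4 (within the scatter), and the two examples of this change agree: the same change on two cores in this assay, no change at the digits printed (within the scatter) from compound 2 to compound 3 and a number 4 percentage points higher (within the scatter) from compound 1 to compound 4, 4 percentage points apart, within the scatter of two such steps. Within what this single concentration can resolve, the change therefore carries from one core to the other without a step that can be told from the scatter. This does not show that the two cores respond alike under conditions where a clear effect is seen, since a pair of steps within the scatter gives no real effect to compare, and two examples do not establish a rule for the series.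

The compounds shown leave open whether any group at this place would produce a step beyond the scatter, for example a hydroxyl, a fluorine atom or a longer alkoxy chain in place of the methoxy. On the carbonyl side, they also leave open what a carboxylic acid or an amide would do in place of the amino group of the 4-aminophenyl ring.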